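A few compounds are considered here, and "the series" means these few. Any claim that something is new, unique, unknown or untested is made for them only; others in the source may bear on it.

Measured so far:
compound 1 `COc1cc(C)cc(-c2c(-c3ccnc(-c4ccc(C(C)=O)cc4)c3)cnn2CC#N)c1`: 109%
compound 2 `COc1cc(C)cc(-c2nn(CC#N)cc2-c2ccnc(-c3ccc(N(C)C)cc3)c2)c1`: 103%

In a functional assay on DU-145 cells (Homo sapiens) for cytotoxicity, read by sulforhodamine B assay, with a stated time of 48 h, tested at 0.001 uM (on this read-out lower numbers stand for a stronger effect and higher numbers for a weaker effect at the one concentration tested), compound 1 gives 109%, the highest of the two numbers shown, while compound 2 gives 103%, a number that sits within the usual scatter of the first, so the two read alike. Compound 3 `COc1cc(C)cc(-c2c(-c3ccnc(-c4ccc(N(C)C)cc4)c3)cnn2CC#N)c1` has not yet been measured. It differs from compound 1 in one place: dimethylamino in place of acetyl on an aromatic carbon. The acetyl leaves and a dimethylamino enters on an aromatic carbon of a six-membered aromatic ring of carbon only, para to a large group. Among the compounds with values here, no measured pair shows this change, so the expected step of a number 5 percentage points lower from compound 1 to compound 3 (within the scatter) is none beyond the scatter. Compound 3 is therefore expected to give 104% in this assay, between 90% and 118%.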

Compound 3, a percentage reported as activity, at one concentration (the size of the read-out at that concentration, not a potency): 102%
For compound 3 the middle estimate is 2 percentage points above the measured one, and the stated range covers the measured number.
By their numbers in this assay, from the lowest: compounds 3, 2 and 1 (each within the scatter of the next).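

Swapping acetyl for dimethylamino on this aromatic carbon, para to a large group, gives the first direct reading of a change at this position: in this assay it amounts to a number 7 percentage points lower from compound 1 to compound 3 (within the scatter). At this single low concentration, these two groups therefore cannot be told apart. Nothing available explains this result.

As far as these compounds go, whether a carboxylic acid or a primary amine at the same position would move the number beyond the scatter stays open. So does whether compound 1 and compound 3 would separate at higher concentrations.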